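The source may report more compounds than this note shows. Statements on the series, on what has been measured and on what is new or still open speak of the compounds shown alone.

Of the compounds shown here, three have been tested in a functional assay on HSC-3 cells (Homo sapiens) for cytotoxicity (on this read-out lower numbers stand for higher toxicity in this test and higher numbers for lower toxicity in this test), and a fourth is still to be measured. Compound 1 `COc1cc(/C=C2\Cc3ccccc3/C(=C\c3ccc([N+](=O)[O-])cc3)C2=O)ccc1O` gives 3800 nM. Compound 2 `COc1ccc(/C=C2\CCC/C(=C\c3ccc([N+](=O)[O-])cc3)C2=O)cc1OC` gives 4400 nM, a number within the scatter of that of compound 1. Compound 3 `O=C1/C(=C/c2ccc(O)cc2)Cc2ccccc2/C1=C\c1ccc([N+](=O)[O-])cc1` gives 14000 nM, the highest of the three.

Compound 3 and compound 1 share a core and differ in one place: methoxy in place of hydrogen on an aromatic carbon. That change produced a 3.7-fold lower number from compound 3 to compound 1 (0.57 log units; beyond the scatter).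

Compound 4 `COc1cc(/C=C2\CCC/C(=C\c3ccc([N+](=O)[O-])cc3)C2=O)cc(OC)c1OC` is the unmeasured compound. It is built on the core of compound 2, and the difference between the cores of compound 2 and compound 3 is not broken down here. From compound 2 to compound 4 the change is methoxy in place of hydrogen on an aromatic carbon. Among the measured compounds shown here, this is the same kind of change as the one from compound 3 to compound 1, but the surroundings of the place differ: in compound 1 the new methoxy sits ortho to a hydroxy group, while in compound 4 it sits ortho to a methoxy group and meta to a methoxy group, in both cases meta to a large group.

For the measured compounds named here, because the earlier step gave a 3.7-fold lower number from compound 3 to compound 1 (0.57 log units; beyond the scatter), a drop in the same direction is expected from compound 2 to compound 4, though with only one precedent in different surroundings the expected step is kept smaller: a 1.5-fold lower number from compound 2 to compound 4 (0.17 log units; within the scatter). In this assay compound 4 is therefore estimated at 3000 nM, likely between 1200 nM and 8000 nM.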

Compound 4, half-maximal cytotoxic concentration: 4700 nM
The estimate for compound 4 lay 1.6-fold (0.19 log units) below the measured number, and the stated range covers the measured number.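

In this assay, putting a methoxy group in place of a hydrogen on an aromatic carbon gave a 1.1-fold higher number from compound 2 to compound 4 (0.03 log units; within the scatter), so compound 2 and compound 4 cannot be told apart on this read-out. Set beside the earlier step, the same change did not carry over from one core to the other: the same change on two cores in this assay, a 3.7-fold lower number (0.57 log units; beyond the scatter) from compound 3 to compound 1 and a 1.1-fold higher number (0.03 log units; within the scatter) from compound 2 to compound 4, 3.9-fold (0.59 log units) apart, beyond the scatter of two such steps This shows that a step seen on the core of compound 3 cannot simply be assumed on the core of compound 2, but it does not show what sets the two steps apart: they differ both in the core and in the groups around the new methoxy, and with only one step on each core these two differences cannot be separated.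

The compounds shown leave open whether the step seen with compound 1 would return on the core of compound 2 if a hydroxy group stood on the ring in place of one of the methoxy groups. They also leave open whether an ethoxy group or an amine entering at the same place would behave as the methoxy group does on either core.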